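This account rests on a few compounds, and the source may have more. Where it says the series, first, only, none or still open, it means among the compounds named here.

Measured compounds in a functional assay on MCF7 cells (Homo sapiens) for inhibition, read by MTT assay, with a stated time of 72 h; a higher number here means a weaker inhibitor of growth, a lower number a stronger inhibitor of growth:
compound 1 `O=S(=O)(NCCCNCc1ccccc1Cl)c1cc(C(F)(F)F)cc(C(F)(F)F)c1`, which in this assay gives 8800 nM
compound 2 `O=S(=O)(NCCCNCc1ccc(C(F)(F)F)cc1)c1cc(C(F)(F)F)cc(C(F)(F)F)c1`, which in this assay gives 1400 nM

Within the data shown here, compound 2 stands at the lower of the two numbers; the only measured step, a 6.3-fold lower number from compound 1 to compound 2 (0.80 log units; beyond the scatter), separates it from compound 1, so compound 2 is the stronger growth inhibitor of the pair.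

Compound 3 `O=S(=O)(NCCCNCc1ccccc1)c1cc(C(F)(F)F)cc(C(F)(F)F)c1` is the next member. It differs from compound 2 by hydrogen in place of trifluoromethyl on an aromatic carbon; the same difference, read one bond further out, is 4-(trifluoromethyl)phenyl to phenyl on the saturated chain carbon bound to the amine nitrogen.

Among the measured compounds shown here, no measured step removes a substituent from this benzyl ring. For the measured compounds named here, the single step on record, a 6.3-fold lower number from compound 1 to compound 2 (0.80 log units; beyond the scatter), exchanges one substituted benzyl for another and bears on the present change only indirectly, in that the 4-(trifluoromethyl)benzyl compound carries the lower number of the two. On that slender basis the unsubstituted benzyl of compound 3 is expected to sit somewhat higher than compound 2, the expected step being a 2.5-fold higher number from compound 2 to compound 3 (0.40 log units; beyond the scatter). Compound 3 is therefore estimated at 3500 nM in this assay, within a range of 1200 nM to 10000 nM.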

Compound 3, concentration for 50% growth inhibition: 3000 nM
Compound 3: the middle estimate sits 1.2-fold (0.07 log units) above what was measured; the range from low to high includes it.
By their numbers in this assay, from the lowest: compound 2; then compound 3; then compound 1.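

With the unsubstituted benzyl of compound 3 as a reference in this assay, the two substituents can now be read separately against hydrogen. Loss of trifluoromethyl from the aromatic carbon para to a large group raises the number (a 2.1-fold higher number from compound 2 to compound 3 (0.33 log units; beyond the scatter)), whereas loss of chloro lowers it (a 2.9-fold lower number from compound 1 to compound 3 (0.47 log units; beyond the scatter)), so the two substituted benzyl compounds lie on opposite sides of compound 3, each by a modest step beyond the scatter. No measurement on hand accounts for either step.

The names 2-chlorophenyl and 4-(trifluoromethyl)phenyl differ in both group and place, so the compounds shown leave open whether the opposite directions follow the group or its place on the ring. Also open, as far as these compounds go, is how a methoxy group, a carboxylic acid or an amine would read at the place held by trifluoromethyl.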